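Mirror image of compound 2 in the ileum assay

The source may report more compounds than this note shows. Statements on the series, on what has been measured and on what is new or still open speak of the compounds shown alone.

Of the compounds shown here, two have been measured so far. Compound 1 `C[C@@H]1O[C@H](C[N+](C)(C)C)CC1(F)F` and compound 2 `C[C@@H]1O[C@@H](C[N+](C)(C)C)CC1(F)F` share the same atoms and bonds and differ only in configuration as drawn (the fact that compounds 1 and 2 differ only in the configuration as drawn). In a functional assay on ileum with muscarinic acetylcholine receptor M3 (Cavia porcellus) as the target (on this read-out lower numbers stand for lower potency and higher numbers for higher potency (the scale is a negative logarithm)), compound 1 gives 5.8, and compound 2 gives 5.33. Within the data shown here, the single inversion produced a number 0.47 log units lower from compound 1 to compound 2 (beyond the scatter), so compound 2 stands lowest of the two numbers, with compound 1 as its only neighbour.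

Compound 3 `C[C@H]1O[C@H](C[N+](C)(C)C)CC1(F)F` is the next step. Compared with compound 2, (the two compounds have the same atoms and bonds and differ only in configuration as drawn: 2 of 2 stereo elements differ (all stereocentres are inverted: mirror images); a stereocentre at a saturated ring carbon is drawn S in compound 2 and R in compound 3; a stereocentre at a saturated ring carbon is drawn R in compound 2 and S in compound 3). Among the measured compounds shown here, the one measured step bears on this only loosely: it shows that inverting a single stereocentre at a saturated ring carbon shifted potency by a modest amount beyond the scatter, from compound 1 to compound 2. For compound 3, where both centres are inverted, a shift of similar size in this assay is plausible, but its direction cannot be read from the two numbers, so an estimate near the middle with a wide range is appropriate. Compound 3 is therefore expected at 5.55, between 4.9 and 6.3, corresponding to an expected step of a number 0.22 log units higher from compound 2 to compound 3 (within the scatter).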

Compound 3, negative logarithm of the half-maximal effective concentration: 4.85
Estimate against measurement, compound 3: 0.70 log units above; the measured number lies below the stated range.
By their numbers in this assay, from the lowest: compound 3; then compound 2; then compound 1.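

Compound 3 is the mirror image of compound 2, yet this assay still tells the two apart, with a number 0.48 log units lower from compound 2 to compound 3 (beyond the scatter); this gap can be traced to configuration alone because of one fact: the fact that compounds 2 and 3 differ only in the configuration as drawn. Compound 3 also differs from compound 1 at a single stereocentre, a different one from the centre that separates compound 1 and compound 2, and that inversion gives a number 0.95 log units lower from compound 1 to compound 3 (beyond the scatter). Each of the two centres therefore counts in this read-out, and compound 1 is the most potent of the three, with both of its steps beyond the scatter.

On these data alone, how the mirror image of compound 1 would sit in this order stays open. All three compounds carry the same atoms and bonds, so they say nothing about changing the groups themselves, such as an ethyl in place of the methyl on the ring or a hydroxyl in place of the two fluorines.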